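The source may hold more compounds than are shown below. What is called first, only, known or untested is meant among the compounds shown, and "the series" means these compounds.

For the measured compounds named here, compound 1 `COC(=O)C1=C(C)N=C(C)/C(=C(\O)OC)C1c1ccccc1Cl` stands lowest of the two numbers measured so far in a functional assay (muscle tissue) with Cavia porcellus as the target; a lower number here means that less compound is needed, a higher number that more compound is needed for the effect: compound 1 gives 2.19 nM, while compound 2 `COC(=O)C1=C(C)N=C(C)/C(=C(\O)OC)C1c1cccc(I)c1` gives 41.7 nM. Going by the values given here, the single measured step, a 19-fold higher number from compound 1 to compound 2 (1.28 log units; beyond the scatter), exchanged the whole substituted ring, putting 3-iodophenyl in place of 2-chlorophenyl, and so it shows that the substituted ring strongly influences the read-out without isolating the role of the chloro group itself.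

Compound 3 `COC(=O)C1=C(C)N=C(C)/C(=C(\O)OC)C1c1ccccc1C(F)(F)F` differs from compound 1 in one place only: trifluoromethyl in place of chloro on an aromatic carbon. Among the compounds with values here, no measured step compares these two groups on the same aromatic carbon, so the step from compound 1 to compound 2 bears on compound 3 only indirectly, as a sign that changes on this ring can be large. Since the ring keeps its substituent on the same carbon, ortho to a large group, the expectation is a step of a 1.6-fold higher number from compound 1 to compound 3 (0.20 log units; within the scatter), not clearly beyond the scatter. Compound 3 is therefore estimated at 3.5 nM, with a range from 1 nM to 12 nM.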

Compound 3, half-maximal effective concentration: 1.51 nM
Beside the measured number, compound 3's estimate is 2.3-fold (0.37 log units) above it, within the range that was stated.
By their numbers in this assay, from the lowest: compounds 3 and 1 (each within the scatter of the next); then compound 2.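

Trifluoromethyl in place of chloro on an aromatic carbon, ortho to a large group, gives a 1.5-fold lower number from compound 1 to compound 3 (0.16 log units; within the scatter) in this assay, and this is the first step shown that changes only the group on this carbon. The entering group has 4 heavy atoms and the leaving group has 1, yet compound 1 and compound 3 cannot be told apart by this read-out, which shows that a substituent with more heavy atoms on this carbon can still keep the number this low, unlike the much larger a 19-fold higher number from compound 1 to compound 2 (1.28 log units; beyond the scatter), where both the group and its place on the ring differ. No measurement shown here explains why the two groups read alike.

The compounds shown leave open how a group with hydrogen-bond donors or acceptors, such as an amine or a carboxylic acid, would read on this aromatic carbon. It also remains open how much of the step to compound 2 belongs to iodo and how much to its place on the ring, as no pair shown carries the same group on two different ring carbons.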